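Trimming Ethoxymethyl to Methoxymethyl

The source may report more compounds than this note shows. Statements on the series, on what has been measured and on what is new or still open speak of the compounds shown alone.

In a functional assay on KB cells (Homo sapiens) for cytotoxicity, read by sulforhodamine B assay, with a stated time of 3 days (a lower number here means that less compound is needed, a higher number that more compound is needed for the effect), compound 1 (`CCOCc1c(C)coc1-c1ccc2c(c1OC)CCCC2(C)C`) gives 21.6 uM and compound 2 (`CCOc1c(-c2occ(C)c2CO)ccc2c1CCCC2(C)C`) gives 16.9 uM on the same measure. These two numbers lie within the usual scatter of each other, so compound 1 stands level with compound 2 on the data so far.

Compound 3 (`COCc1c(C)coc1-c1ccc2c(c1OC)CCCC2(C)C`) differs from compound 1 in one place (hydrogen in place of methyl on a saturated chain carbon bound to an oxygen on a saturated carbon): hydrogen in place of methyl on a saturated chain carbon bound to an oxygen on a saturated carbon, which turns ethoxymethyl into methoxymethyl. For the measured compounds named here, no measured pair shows this change on its own, so the expectation rests on the two numbers at hand. In this assay no step beyond the scatter is expected, and neither direction is favoured. The estimated step of a 1.0-fold higher number from compound 1 to compound 3 (0.01 log units; within the scatter) is expected to stay small. Compound 3 is expected to give 22 uM with an estimated range from 11 uM to 45 uM around that middle.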

Compound 3, concentration for half-maximal effect: 11.5 uM
Estimate against measurement, compound 3: 1.9-fold (0.28 log units) above, within the range that was stated.
By their numbers in this assay, from the lowest: compounds 3, 2 and 1 (each within the scatter of the next).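

For the compounds shown here, this is the first measured pair in which only the ethoxymethyl group changes, here to methoxymethyl, and in this assay the step reads a 1.9-fold lower number from compound 1 to compound 3 (0.27 log units; within the scatter) on the shared core. Swapping methyl for hydrogen on this saturated chain carbon therefore stays inside the usual scatter, so ethoxy and methoxy cannot be told apart at this place on this measure. Nothing available here explains the size of this step.

Going by these compounds, this single pair covers only ethoxymethyl and methoxymethyl, so it remains open how a longer chain such as propoxymethyl, or an amine or a carboxylic acid at the same place, would read. It also leaves open whether the same swap would stay within the scatter on a different core.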